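Replacing the phenyl of compound 3 with methylcarbamoyl

A few compounds are considered here, and "the series" means these few. Any claim that something is new, unique, unknown or untested is made for them only; others in the source may bear on it.

In a functional assay on the whole organism for inhibition, with Rattus norvegicus as the target (a lower number here means that less compound is needed, a higher number that more compound is needed for the effect), three compounds built on one shared core have been measured. Compound 1 `CCOc1ccc(N/N=C2\CCC(C)n3c2ncc(C(=O)O)c3=O)cc1` gives 1.6 umol/kg, compound 2 `CC1CC/C(=N\Nc2ccc(C(F)(F)F)cc2)c2ncc(C(=O)O)c(=O)n21` gives 38.6 umol/kg, and compound 3 `CC1CC/C(=N\Nc2ccc(-c3ccccc3)cc2)c2ncc(C(=O)O)c(=O)n21` gives 1.1 umol/kg. Compound 3 stands at the lowest number of the three: its nearest neighbour is compound 1, where the step of a 1.5-fold lower number from compound 1 to compound 3 (0.16 log units; within the scatter) lies within the scatter, while the step of a 35-fold lower number from compound 2 to compound 3 (1.55 log units; beyond the scatter) is large and beyond it. Compound 4 `CNC(=O)c1ccc(N/N=C2\CCC(C)n3c2ncc(C(=O)O)c3=O)cc1` differs from compound 3 in one place: methylcarbamoyl in place of phenyl on an aromatic carbon. Within the data shown here, no measured step exchanges phenyl for methylcarbamoyl, so none bears directly on this change; the two steps that involve phenyl, a 1.5-fold lower number from compound 1 to compound 3 (0.16 log units; within the scatter) and a 35-fold lower number from compound 2 to compound 3 (1.55 log units; beyond the scatter), show only that the group at this position can move the number a little or a great deal. Compound 4 is therefore estimated at 5 umol/kg, within a range from 1 umol/kg to 40 umol/kg, which means an expected step of a 4.5-fold higher number from compound 3 to compound 4 (0.66 log units; beyond the scatter), with the direction toward a higher number considered more likely than a lower one.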

Compound 4, dose for 50% inhibition: 9.6 umol/kg
Estimate against measurement, compound 4: 1.9-fold (0.28 log units) below; measured number inside the range.
By their numbers in this assay, from the lowest: compounds 3 and 1 (each within the scatter of the next); then compound 4; then compound 2.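

In this assay, methylcarbamoyl, the only group shown here with a hydrogen-bond donor, gives an 8.7-fold higher number from compound 3 to compound 4 (0.94 log units; beyond the scatter) and a 6.0-fold higher number from compound 1 to compound 4 (0.78 log units; beyond the scatter) in exchange for phenyl and ethoxy. Yet this group does not go as far as trifluoromethyl, as a 4.0-fold lower number from compound 2 to compound 4 (0.60 log units; beyond the scatter) shows, so compound 4 sits between compounds 1 and 3 on one side and compound 2 on the other, and the position gives graded results rather than a split into two levels. Nothing measured here accounts for this placing.

The change from phenyl removes a ring and adds a donor in one step, so the compounds shown do not separate these two differences. On these data alone, how dimethylcarbamoyl, a longer chain on the amide nitrogen, or a carboxylic acid at this position would read also remains open.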